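The source may report more compounds than this note shows. Statements on the series, on what has been measured and on what is new or still open speak of the compounds shown alone.

Of the compounds shown here, three from this series have been tested so far in a functional assay on the whole organism (strain Wistar albino) for inhibition, with Rattus norvegicus as the target, read by paw edema, with a stated time of 1 h, at a dose of 40 mg/kg by the oral route; on this read-out lower numbers stand for less inhibition and higher numbers for more inhibition at the one dose given (going by the name of the read-out). Compound 1 `Cc1nc(-c2ccc(Cl)cc2)sc1C1SCC(=O)N1c1ccc(F)c(Cl)c1` gives 53.4%, compound 2 `Cc1nc(Cc2ccc(Cl)cc2)sc1C1SCC(=O)N1c1ccc(F)c(Cl)c1` gives 40.7%, and compound 3 `COc1ccc(N2C(=O)CSC2c2sc(-c3ccccc3)nc2C)cc1` gives 52.3%. On these numbers compound 3 stands second of three: its gap to compound 1 lies within the scatter, while its gap to compound 2 lies beyond it. Within the data shown here, the one step between measured compounds that differ in a single place is a number 12.7 percentage points lower from compound 1 to compound 2 (beyond the scatter), which concerns the group on an aromatic carbon and not the amide-type nitrogen in a ring.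

The next compound, compound 4 `Cc1nc(-c2ccccc2)sc1C1SCC(=O)N1c1ccc(F)c(Cl)c1`, is reached from compound 3 by a single change: 3-chloro-4-fluorophenyl in place of 4-methoxyphenyl on an amide-type nitrogen in a ring. Among the measured compounds shown here, no measured step touches this position, so the change from compound 3 to compound 4 has no direct precedent. What can be said is that compound 1, which carries the same 3-chloro-4-fluorophenyl group on the amide-type nitrogen as compound 4, sits within the scatter of compound 3 in this assay. Compound 4 is therefore expected to show no step beyond the scatter, an estimated change of a number 2.3 percentage points lower from compound 3 to compound 4 (within the scatter). The estimate for compound 4 is 50%, between 38% and 62%.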

Compound 4, a percentage reported as inhibition, in the whole organism at one dose (the size of the read-out at that dose, not a potency): 55.9%
Compound 4: middle estimate off by 5.9 percentage points, on the low side; measured number inside the range.
By their numbers in this assay, from the lowest: compound 2; then compounds 3, 1 and 4 (each within the scatter of the next).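

In this assay, the step at the amide-type nitrogen in a ring is a number 3.6 percentage points higher from compound 3 to compound 4 (within the scatter). At this one dose and time, the 3-chloro-4-fluorophenyl and 4-methoxyphenyl groups therefore cannot be told apart on that nitrogen, even though they share no substituent atoms and only the 4-methoxyphenyl group carries a hydrogen-bond acceptor. The new compound also separates two changes on the aromatic carbon: hydrogen in place of chloro gives a number 2.5 percentage points higher from compound 1 to compound 4 (within the scatter), whereas phenyl in place of 4-chlorobenzyl gives a number 15.2 percentage points higher from compound 2 to compound 4 (beyond the scatter), so among these compounds only the 4-chlorobenzyl group of compound 2 goes with a step beyond the scatter. Nothing available here explains why either step has the size it has.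

Among these compounds, only two aryl groups on the amide-type nitrogen are compared with the rest of the molecule held the same, so it remains open whether a simple unsubstituted phenyl, a 4-aminophenyl or a 4-carboxyphenyl group, or a longer alkyl chain in their place, would also stay within the scatter. On these data alone, it is also open whether an unsubstituted benzyl group on the aromatic carbon would give a step like that of the 4-chlorobenzyl group.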